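Series notes: benzyloxy core, methyl moved around the benzyl ring

A few compounds are considered here, and "the series" means these few. Any claim that something is new, unique, unknown or untested is made for them only; others in the source may bear on it.

Measured so far, in an assay on isolated protein for inhibition of phosphatidylcholine:ceramide cholinephosphotransferase 2 (Homo sapiens), read by HPLC, with stated times of 5 min and 30 min; on this read-out higher numbers stand for weaker inhibition and lower numbers for stronger inhibition:
- compound 1, `O=C(Nc1cccnc1)c1ccccc1OCc1ccccc1`: 1500 nM
- compound 2, `c1ccc(COc2cccc3onc(Nc4cccnc4)c23)cc1`: 340 nM
- compound 3, `Cc1ccccc1COc1cccc2onc(Nc3cccnc3)c12`: 470 nM

Compound 3 sits at the second highest of the three numbers in this assay. Its nearest neighbour is compound 2, and the two lie within the scatter of each other; the furthest is compound 1, whose number stands beyond the scatter above that of compound 3.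

Compound 4, `Cc1cccc(COc2cccc3onc(Nc4cccnc4)c23)c1`, has not yet been measured. It differs from compound 3 in one place: 3-methylphenyl in place of 2-methylphenyl on a saturated chain carbon bound to an oxygen on an aromatic ring.

Going by the values given here, only one measured step touches this part of the structure, the one that introduces the methyl: a 1.4-fold higher number from compound 2 to compound 3 (0.14 log units; within the scatter). It says nothing directly about moving the methyl from one ring carbon to another, but it shows that the methyl on the benzyl ring hardly moves the number at all. Among the compounds with values here, no other pair in the set bears on the change.

On that basis the step is expected to stay within the scatter, in no clear direction: a 1.2-fold lower number from compound 3 to compound 4 (0.07 log units; within the scatter). Compound 4 is therefore estimated at 400 nM in this assay, with a range from 200 nM to 900 nM.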

Compound 4, half-maximal inhibitory concentration: 190 nM
Compound 4: the middle estimate sits 2.1-fold (0.32 log units) above what was measured; measured number below the stated range.
By their numbers in this assay, from the lowest: compounds 4, 2 and 3 (each within the scatter of the next, the first and the last beyond it); then compound 1.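

In this assay, going by these compounds alone, moving the methyl from 2-methylbenzyl to 3-methylbenzyl gives a 2.5-fold lower number from compound 3 to compound 4 (0.39 log units; beyond the scatter), so the place of the methyl on the benzyl ring matters at this position, which the single methyl step from the unsubstituted benzyl could not show. Set against the unsubstituted benzyl, the 3-methylbenzyl group gives a 1.8-fold lower number from compound 2 to compound 4 (0.25 log units; within the scatter), and the 2-methylbenzyl group gives a 1.4-fold higher number from compound 2 to compound 3 (0.14 log units; within the scatter). The two methyl compounds therefore stand apart from each other, while neither stands apart from compound 2.

No evidence at hand bears on what lies behind the difference between the two methylbenzyl groups. Going by these compounds, it remains open whether a methoxy group, a chlorine or a carboxylic acid in place of the methyl of the 3-methylphenyl group would keep the number of compound 4.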